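A few compounds are considered here, and "the series" means these few. Any claim that something is new, unique, unknown or untested is made for them only; others in the source may bear on it.

Among the measured compounds shown here, in a functional assay on HCT-15 cells (Homo sapiens) for antiproliferative activity, read by MTT assay, with a stated time of 72 h (a lower number here means a stronger inhibitor, a higher number a weaker inhibitor), compound 2 `COc1ccc(-n2ccnc2-c2cc(OC)c(OC)c(OC)c2)cc1[N+](=O)[O-]` gives 1000 nM, the only actual number available so far. Compound 1 `COc1cc(-c2nccn2C)cc(OC)c1OC` has only a limit of the assay, > 100000 nM, and not a number. Compound 2 therefore provides the single firm reference point for what follows.

Compound 3 `COc1ccc(-n2ccnc2-c2cc(OC)c(OC)c(OC)c2)cc1` differs from compound 2 in one place, with hydrogen in place of nitro on an aromatic carbon, ortho to a methoxy group (hydrogen in place of nitro on an aromatic carbon). For the measured compounds named here, no measured pair here shows what this swap does, so any forecast must remain loose and must start from the value of compound 2. A moderate gain in strength is expected in this assay, with an estimated 2.5-fold lower number from compound 2 to compound 3 (0.40 log units; beyond the scatter), although a change in the opposite direction cannot be excluded. Compound 3 is expected to give about 400 nM, within an estimated range of 40 nM to 4000 nM.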

Compound 3, half-maximal inhibitory concentration: 1300 nM
Estimate against measurement, compound 3: 3.3-fold (0.51 log units) below; measured number inside the range.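

In this assay, hydrogen in place of nitro on this aromatic carbon, ortho to a methoxy group, gives a 1.3-fold higher number from compound 2 to compound 3 (0.11 log units; within the scatter), so the two compounds cannot be told apart and the nitro group is not required for activity at this level. Compound 3 also allows a comparison that differs in one place, and 4-methoxyphenyl in place of methyl on the aromatic nitrogen gives an at least 76-fold lower number from compound 1 to compound 3 (1.88 log units; beyond the scatter), a far larger step than the one at the nitro position. The true size of that step is unknown, since compound 1 has only a limit and not a number: the limit of > 100000 nM in this assay, at which 1 of the 3 values shown sits.

As far as these compounds go, only nitro and hydrogen are compared on this carbon, so it remains open whether an amine or a carboxylic acid there would give a different number. From the compounds shown here alone, the effect of a longer chain in place of the methoxy group also remains open.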